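Substituted benzamides on a shared flavonol core against MCF7 cells

The source may report more compounds than this note shows. Statements on the series, on what has been measured and on what is new or still open speak of the compounds shown alone.

Compound 1 `Cc1ccccc1C(=O)Nc1cccc(-c2oc3cc(-c4ccc(F)cc4)ccc3c(=O)c2O)c1`: 2280 nM
Compound 2 `COc1cccc(C(=O)Nc2cccc(-c3oc4cc(-c5ccc(F)cc5)ccc4c(=O)c3O)c2)c1`: 15300 nM
Compound 3 `O=C(Nc1cccc(-c2oc3cc(-c4ccc(F)cc4)ccc3c(=O)c2O)c1)c1cccc(F)c1`: 5770 nM

Three compounds share one core and differ only in the aryl group on a carbonyl carbon. In a functional assay on MCF7 cells (Homo sapiens) for antiproliferative activity, read by CCK-8 assay, with a stated time of 72 h (a lower number here means a stronger inhibitor, a higher number a weaker inhibitor), compound 1 gives 2280 nM, compound 2 gives 15300 nM and compound 3 gives 5770 nM. Compound 3 stands second highest of the three: a 2.5-fold higher number from compound 1 to compound 3 (0.40 log units; beyond the scatter), while a 2.7-fold lower number from compound 2 to compound 3 (0.42 log units; beyond the scatter).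

Compound 4 `O=C(Nc1cccc(-c2oc3cc(-c4ccc(F)cc4)ccc3c(=O)c2O)c1)c1ccc([N+](=O)[O-])cc1` is not yet measured. It differs from compound 3 in one place: 4-nitrophenyl in place of 3-fluorophenyl on a carbonyl carbon. All three measured steps change the aryl group on this same carbonyl carbon, and each was modest: a 6.7-fold higher number from compound 1 to compound 2 (0.83 log units; beyond the scatter), a 2.5-fold higher number from compound 1 to compound 3 (0.40 log units; beyond the scatter) and a 2.7-fold lower number from compound 2 to compound 3 (0.42 log units; beyond the scatter). None of them involves a nitrophenyl group, so the direction for compound 4 is open; the measured steps suggest a change of modest size at most, and a result near that of compound 3 is the plainest expectation.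

Compound 4 is therefore estimated to give 6500 nM, with a range from 2000 nM to 20000 nM. This estimate corresponds to an expected step of a 1.1-fold higher number from compound 3 to compound 4 (0.05 log units; within the scatter).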

Compound 4, half-maximal inhibitory concentration: 3970 nM
Beside the measured number, compound 4's estimate is 1.6-fold (0.21 log units) above it, and the stated range covers the measured number.
By their numbers in this assay, from the lowest: compounds 1, 4 and 3 (each within the scatter of the next, the first and the last beyond it); then compound 2.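

In this assay, 4-nitrophenyl on the carbonyl carbon stays level with both 3-fluorophenyl (a 1.5-fold lower number from compound 3 to compound 4 (0.16 log units; within the scatter)) and 2-methylphenyl (a 1.7-fold higher number from compound 1 to compound 4 (0.24 log units; within the scatter)), even though compound 1 and compound 3 lie apart beyond the scatter. Going from 7 heavy atoms to 9 and from 0 hydrogen-bond acceptors to 2 therefore leaves compound 4 within the scatter of compound 3. Only the 3-methoxyphenyl group of compound 2 stands clearly apart (a 3.9-fold lower number from compound 2 to compound 4 (0.59 log units; beyond the scatter)).

Nothing shown here accounts for these values. Going by these compounds, it remains open how an aminophenyl or carboxyphenyl group would compare at this carbonyl carbon, and whether 3-nitrophenyl would match 4-nitrophenyl.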